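Butyl in place of the ether-bearing side chain

The source may report more compounds than this note shows. Statements on the series, on what has been measured and on what is new or still open speak of the compounds shown alone.

Three compounds of the series have numbers in an in vitro assay on 293-EBNA cells for binding affinity to corticotropin-releasing factor receptor 1 (Homo sapiens); on this read-out higher numbers stand for weaker inhibition and lower numbers for stronger inhibition. Compound 1 `CCCC(C)Nc1nc(C)nc2c1nnn2-c1c(C)cc(C)cc1C` gives 7.1 nM. Compound 2 `COCC(COC)Nc1nc(C)nc2c1nnn2-c1ccc(C(C)C)cc1Br` gives 10.3 nM, the highest of the three; against compound 1 this lies within the scatter, against compound 3 beyond it. Compound 3 `CCCCN(CC)c1nc(C)nc2c1nnn2-c1c(Br)cc(OC)cc1OC` gives 3 nM, the lowest of the three.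

The next step starts from compound 2 and leads to compound 4 `CCCCNc1nc(C)nc2c1nnn2-c1ccc(C(C)C)cc1Br`. The change is butyl in place of 2-methoxy-1-(methoxymethyl)ethyl on a nitrogen on an aromatic ring. No pair of the measured compounds differs in just one place, so no measured step speaks directly to this change; compounds 1 and 3, which carry plain alkyl groups on the same nitrogen, only show lower numbers than compound 2 without isolating the cause.

For this assay the expected step is a 1.7-fold lower number from compound 2 to compound 4 (0.23 log units; within the scatter), a small move toward lower numbers that may well stay within the scatter. Compound 4 is therefore estimated at 6 nM, with a range from 2 nM to 18 nM.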

Compound 4, inhibition constant: 69.6 nM
For compound 4 the middle estimate is 12-fold (1.06 log units) below the measured one; the whole stated range lies below it.
By their numbers in this assay, from the lowest: compound 3; then compounds 1 and 2 (each within the scatter of the next); then compound 4.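

In this assay, among these compounds, butyl in place of 2-methoxy-1-(methoxymethyl)ethyl on this nitrogen gives a 6.8-fold higher number from compound 2 to compound 4 (0.83 log units; beyond the scatter) and is the first single-place change read. With the rest of compound 2 held fixed, this position clearly responds to the side chain, and the ether-bearing group gives the stronger inhibition of the two. The data at hand offer nothing that explains this step.

The pair does not separate the two ether oxygens from the branched shape of the leaving group, so a 2-methoxyethyl chain and a 1-ethylpropyl group on the same nitrogen are the open comparisons. As far as these compounds go, it also remains open whether the step carries over to the other aromatic substituent patterns of compounds 1 and 3.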